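Swapping dimethylamino for diethylamino on the amide side chain

The source may report more compounds than this note shows. Statements on the series, on what has been measured and on what is new or still open speak of the compounds shown alone.

Measured in a functional assay on MCF7 cells (Homo sapiens), read by MTT assay, with a stated time of 48 h; a higher number here means a weaker inhibitor, a lower number a stronger inhibitor:
- compound 1 `CCn1c(C(=O)NCCN(C)C)ccc1C(CC)(CC)c1ccc(OCC(=O)C(C)(C)C)c(C)c1`: 520 nM
- compound 2 `CCn1c(C(=O)NCCCN(C)C)ccc1C(CC)(CC)c1ccc(OCC(=O)C(C)(C)C)c(C)c1`: 340 nM

Compound 2 (340 nM) has a single measured neighbour, and the gap to it stays within the scatter, so the two values do not separate. Compound 3 `CCN(CC)CCCNC(=O)c1ccc(C(CC)(CC)c2ccc(OCC(=O)C(C)(C)C)c(C)c2)n1CC` is still to be measured. It carries diethylamino in place of dimethylamino on a saturated chain carbon, three bonds along the chain from an amide-type nitrogen and is otherwise the same as compound 2.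

For the measured compounds named here, the only measured step is a 1.5-fold lower number from compound 1 to compound 2 (0.18 log units; within the scatter) and it alters chain length, not the groups on the amine nitrogen. Going by the values given here, it therefore bears on this change only indirectly, and no measured pair tests the change itself. What it does show is that one edit in this side chain left this assay without a step beyond the scatter. The expected step is a 1.1-fold lower number from compound 2 to compound 3 (0.03 log units; within the scatter) and would lie within the scatter, with no direction favoured. For compound 3 the estimated value is 320 nM, with an expected range from 140 nM to 720 nM, a range kept wide since the evidence is thin.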

Compound 3, half-maximal inhibitory concentration: 530 nM
The estimate for compound 3 lay 1.7-fold (0.22 log units) below the measured number; low and high end bracket the measured number.
By their numbers in this assay, from the lowest: compounds 2, 1 and 3 (each within the scatter of the next).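

In this assay, the first direct test of this change, diethylamino in place of dimethylamino on a saturated chain carbon, three bonds along the chain from an amide-type nitrogen, gives a 1.6-fold higher number from compound 2 to compound 3 (0.19 log units; within the scatter), so at this position the two amine groups do not separate. The edit that reaches the 3-(diethylamino)propyl side chain from the side chain of compound 1 gives a 1.0-fold higher number from compound 1 to compound 3 (0.01 log units; within the scatter), so this replacement does not separate them either. No independent evidence bears on these results.

As far as these compounds go, whether the terminal amine tolerates a wider range of groups in this assay remains open, as a primary amine or a carboxylic acid at the end of the side chain would test a more distant replacement than diethylamino does. From the compounds shown here alone, a longer chain carrying dimethylamino or diethylamino is also open, and would show whether any edit in this side chain gives a step beyond the scatter.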